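This account rests on a few compounds, and the source may have more. Where it says the series, first, only, none or still open, it means among the compounds named here.

Measured so far in a functional assay on NCI/ADR-RES cells (Homo sapiens) for inhibition, read by sulforhodamine B assay, with a stated time of 48 h; a lower number here means a stronger inhibitor of growth, a higher number a weaker inhibitor of growth:
compound 1, `Nc1cc(N)c2nc(-c3ccccc3)c(Sc3ccc(F)cc3)nc2c1`, 16600 nM
compound 2, `COc1cc(CNc2nc3cc(N)cc(N)c3nc2-c2ccccc2)cc(OC)c1OC`, 10200 nM

Compound 1 has the higher of the two numbers, but its gap to compound 2 lies within the scatter, so the two are not separated on these data.

Compound 3, `COc1ccc(Sc2nc3cc(N)cc(N)c3nc2-c2ccccc2)cc1`, is not yet measured. It differs from compound 1 in one place: methoxy in place of fluoro on an aromatic carbon. For the measured compounds named here, no measured pair shows this change, so nothing here says which way it goes. The expectation is no step beyond the scatter, with the estimated step from a 1.2-fold lower number from compound 1 to compound 3 (0.07 log units; within the scatter). Compound 3 is thus expected at about 14000 nM, in a range from 5000 nM to 40000 nM.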

Compound 3, concentration for 50% growth inhibition: < 100000 nM
Compound 3: only a limit was reported; the forecaster's own chance of this, stated with the estimate: 5%; the middle value is on the limit's open side.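

For compound 3, < 100000 nM in this assay is a limit and not a number, so no step can be read between compound 1 and compound 3. From the compounds shown here alone, what methoxy in place of fluoro on an aromatic carbon does to growth inhibition stays open.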